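Inverting one saturated ring stereocentre

The source may hold more compounds than are shown below. What is called first, only, known or untested is meant among the compounds shown, and "the series" means these compounds.

- Compound 1 `CC[C@@H]1C(=O)N(C)c2cnc(-c3cn[nH]c3-c3ccc(F)cc3F)nc2N1c1cnn(C)c1` in an ADME assay on microsomes from liver (Mus musculus) for metabolic stability, with a stated time of 30 min, tested at 1 uM; on this read-out lower numbers stand for a less stable compound and higher numbers for a more stable compound: 5%
- Compound 2 `CC[C@@H]1C(=O)N(C)c2cnc(-n3ccnc3-c3ccccc3)nc2N1[C@@H]1CCOC1` in this assay: 27%

Compound 2 holds the higher of the two numbers, and its gap to compound 1 lies beyond the scatter. The two compounds differ in more than one place, so this gap says nothing about any single change.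

Compound 3 `CC[C@@H]1C(=O)N(C)c2cnc(-n3ccnc3-c3ccccc3)nc2N1[C@H]1CCOC1` has the same atoms and bonds as compound 2 and differs only in configuration as drawn (the two compounds have the same atoms and bonds and differ only in configuration as drawn: 1 of 2 stereo elements differ; a stereocentre at a saturated ring carbon is drawn R in compound 2 and S in compound 3): a stereocentre at a saturated ring carbon is drawn R in compound 2 and S in compound 3. Among the measured compounds shown here, no measured pair shows the effect of such an inversion in this assay, so the data favour no direction. The anchor is compound 2 at 27%. The expected a number 2 percentage points lower from compound 2 to compound 3 (within the scatter) stays within the scatter, although a larger move cannot be excluded. Compound 3 is estimated at 25%, with an expected range of 8% to 50%.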

Compound 3, percent of the compound remaining in the liver assay: 51%
For compound 3 the middle estimate is 26 percentage points below the measured one; measured number above the stated range.
By their numbers in the liver assay, from the lowest: compound 1; then compound 2; then compound 3.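

Among the compounds shown here, in the liver assay the saturated ring stereocentre is the first single change that can be read, with compound 2 at 27% and compound 3 at 51%, which is a number 24 percentage points higher from compound 2 to compound 3 (beyond the scatter), so the form drawn S is the more stable of this pair. In a physicochemical assay for lipophilicity (a lower number here means a more polar compound, a higher number a more lipophilic compound), compound 2 gives 1.8 and compound 3 gives 1.9, which is a number 0.10 log units higher from compound 2 to compound 3 (within the scatter), so the gap in the liver assay has no counterpart beyond the scatter on that read-out. The gap can be assigned to the inversion alone, since nothing else separates the two structures: the fact that compounds 2 and 3 differ only in the configuration as drawn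

One pair cannot show whether the S form keeps its lead when the phenyl-bearing imidazole part of the shared core is replaced, for example by the difluorophenyl pyrazole of compound 1. It also leaves open how a stereocentre-free group at this position, such as an open-chain methoxyethyl group or a piperidine amine, would compare with either form.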